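A few compounds are considered here, and "the series" means these few. Any claim that something is new, unique, unknown or untested is made for them only; others in the source may bear on it.

For the measured compounds named here, in an ADME assay on HEK293 cells (Homo sapiens) for cytotoxicity, read by WST assay (on this read-out higher numbers stand for lower toxicity in this test and lower numbers for higher toxicity in this test), compound 1 (`CC(C)(C)c1ccc(C(=O)OCc2ccc(C=O)cc2)cc1C(C)(C)C`) reads 34000 nM and stands lowest of the two numbers so far, while compound 2 (`CC(C)(C)c1cccc(C(=O)OCc2ccc(C=O)cc2)c1`) reads 73000 nM in the same test. Compound 3 (`CC(C)(C)c1ccc(C(=O)OCc2ccc(C=O)cc2)cc1`) has no number yet. Going to it from compound 1 puts hydrogen in place of tert-butyl on an aromatic carbon, at a carbon ortho to a tert-butyl group and meta to a large group. Going by the values given here, one measured step bears on this: a 2.1-fold higher number from compound 1 to compound 2 (0.33 log units; beyond the scatter) is the same kind of replacement, made at the other tert-butyl group of compound 1, and it is modest, though beyond the scatter. The data do not show whether the two tert-butyl groups count alike, and the expectation carries a wide margin. Going by that single step, a modest rise of similar size is expected in this assay, and the expected step reads a 2.0-fold higher number from compound 1 to compound 3 (0.30 log units; within the scatter) in this estimate. For compound 3 the estimated value is 68000 nM with an expected range from 36000 nM to 130000 nM in this test.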

Compound 3, half-maximal cytotoxic concentration: 63000 nM
Compound 3: the middle estimate sits 1.1-fold (0.03 log units) above what was measured, within the range that was stated.
By their numbers in this assay, from the lowest: compounds 1, 3 and 2 (each within the scatter of the next, the first and the last beyond it).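

At the carbon ortho to a tert-butyl group and meta to a large group, hydrogen in place of tert-butyl gives a 1.9-fold higher number from compound 1 to compound 3 (0.27 log units; within the scatter) in this assay, so compound 1 and compound 3 cannot be told apart in this test. For the compounds shown here, this is the first reading of the change at this position; the only earlier step, a 2.1-fold higher number from compound 1 to compound 2 (0.33 log units; beyond the scatter), was made at the other tert-butyl group and lies beyond the scatter. With one step on each side of the scatter limit and a single example at each position, the two tert-butyl groups cannot be ranked, and the series shows no firm difference between them. No measurement at hand offers an explanation for either step.

The compounds shown leave open how the core would read in this assay with hydrogen in place of both tert-butyl groups, which would show whether the two replacements add up. They also leave open what a methyl group, an amine or a carboxylic acid would give at this position in place of tert-butyl.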